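The compounds below may be only part of what the source reports. "The series", "measured", "known", "first", "only" and "open" are said of these compounds alone.

In a functional assay on SK-OV-3 cells (Homo sapiens) for inhibition, read by CCK-8 assay, with a stated time of 70 h (on this read-out higher numbers stand for weaker inhibition and lower numbers for stronger inhibition), three compounds built on a shared core have been measured. Compound 1 `COc1ccc(COc2ccc(OCCOCCNC3CCCC3)cc2)cc1` gives 15700 nM, and compound 2 `Nc1ccccc1COc1ccc(OCCOCCNC2CCCC2)cc1` gives 14000 nM; these two sit close together, as a 1.1-fold lower number from compound 1 to compound 2 (0.05 log units; within the scatter) shows. Compound 3 `O=C(O)c1ccccc1COc1ccc(OCCOCCNC2CCCC2)cc1` gives > 100000 nM, which is a limit of the assay and not a number. It therefore stands at the limit of > 100000 nM in this assay, at which 1 of the 3 values shown sits.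

Compound 4 `COC(=O)c1ccc(COc2ccc(OCCOCCNC3CCCC3)cc2)cc1` has 4-(methoxycarbonyl)phenyl in place of 2-carboxyphenyl on a saturated chain carbon bound to an oxygen on an aromatic ring. Going by the values given here, two measured steps bear on this change, an at least 6.3-fold higher number from compound 1 to compound 3 (0.80 log units; beyond the scatter) and an at least 7.1-fold higher number from compound 2 to compound 3 (0.85 log units; beyond the scatter), and both lead to the only compound here that carries a free carboxy group. Compound 4 no longer has that group, so it is expected to return to the level of compound 1, at 15700 nM, although no ester has yet been measured in this assay. The expected change toward stronger inhibition is an at least 6.6-fold lower number from compound 3 to compound 4 (0.82 log units; beyond the scatter). For compound 4, the estimated value is 15000 nM, with an expected range from 5000 nM to 45000 nM.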

Compound 4, half-maximal inhibitory concentration: 6990 nM
For compound 4 the middle estimate is 2.1-fold (0.33 log units) above the measured one; low and high end bracket the measured number.
By their numbers in this assay, from the lowest: compounds 4, 2 and 1 (each within the scatter of the next, the first and the last beyond it). At a limit, above all of these: compound 3.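

Putting 4-(methoxycarbonyl)phenyl in place of 2-carboxyphenyl on this saturated chain carbon gives an at least 14-fold lower number from compound 3 to compound 4 (1.15 log units; beyond the scatter), so a ring carrying a carbonyl group at this place does not by itself go with the loss of inhibition. Compound 3 stands at a limit of the assay, not at a number. Methoxycarbonyl in place of methoxy gives a 2.2-fold lower number from compound 1 to compound 4 (0.35 log units; beyond the scatter), so the ester does more than return to the earlier level, while the comparison with the aminophenyl compound gives a 2.0-fold lower number from compound 2 to compound 4 (0.30 log units; within the scatter).

Compound 3 and compound 4 differ both in the group and in where it sits on the ring, and these two changes cannot be told apart here. As far as these compounds go, how an amide or a nitrile in place of methoxycarbonyl would read in this assay also stays open.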